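Chloro to Methyl on Two Related Diazabicyclic Cores

The source may hold more compounds than are shown below. What is called first, only, known or untested is meant among the compounds shown, and "the series" means these compounds.

Compound 1, `Clc1ccc(Nc2ccc(N3CC4CC(C3)N4)cn2)cc1`, was tested in an assay on cell membranes for displacement of a labelled ligand from Neuronal acetylcholine receptor; alpha4/beta2 (Rattus norvegicus); a lower number here means a stronger inhibitor, a higher number a weaker inhibitor; there compound 1 gives 2.49 nM. Compound 2, `Cc1ccc(Nc2ccc(N3CC4CC(C3)N4)cn2)cc1`, differs from compound 1 by methyl in place of chloro on an aromatic carbon, and in this assay compound 2 gives 52.1 nM. That single change produced a 21-fold higher number from compound 1 to compound 2 (1.32 log units; beyond the scatter). Compound 3, `Clc1ccc(Nc2ccc(N3CC4CC(C3)N4)nn2)cc1`, carries a second core; how its core differs from that of compound 1 is not broken down here. In this assay compound 3 gives 90.4 nM, a number close to that of compound 2 and far from that of compound 1.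

Compound 4, `Cc1ccc(Nc2ccc(N3CC4CC(C3)N4)nn2)cc1`, has not yet been measured. It differs from compound 3 by methyl in place of chloro on an aromatic carbon, the same change as that between compound 1 and compound 2, made at the same place. Among the compounds with values here, since the only measured instance of this change gave a 21-fold higher number from compound 1 to compound 2 (1.32 log units; beyond the scatter), a step of similar size is expected from compound 3 onward; the estimate is a 17-fold higher number from compound 3 to compound 4 (1.22 log units; beyond the scatter). Compound 4 is therefore expected to give about 1500 nM in this assay, with a range estimated from 400 nM to 6000 nM.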

Compound 4, inhibition constant: 44.3 nM
Estimate against measurement, compound 4: 34-fold (1.53 log units) above; the measured number lies below the stated range.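

In this assay, methyl in place of chloro on the core of compound 3 gave a 2.0-fold lower number from compound 3 to compound 4 (0.31 log units; beyond the scatter) and so ran in the opposite direction to the same change on the core of compound 1. This shows that, in this series, neither the size nor the direction of the step carried over from one core to the other, but with a single pair on each core it does not show why the two differ, nor whether any other change would depend on the core in the same way. The two steps are clearly distinct, and a step measured on one of these cores therefore gave no reliable guide to the other: the same change on two cores in this assay, a 21-fold higher number (1.32 log units; beyond the scatter) from compound 1 to compound 2 and a 2.0-fold lower number (0.31 log units; beyond the scatter) from compound 3 to compound 4, 43-fold (1.63 log units) apart, beyond the scatter of two such steps.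

The compounds shown carry only chloro or methyl at this place on either core, so it stays open how a methoxy group, a nitrile or an amine would behave there. As far as these compounds go, it also stays open whether such groups would show a similar gap between the two cores.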